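Removing a fluorine: from compound 3 to compound 4

The source may report more compounds than this note shows. Statements on the series, on what has been measured and on what is new or still open speak of the compounds shown alone.

Measured compounds and their values:
compound 1 `Cc1cccc(-c2noc(COc3ccc(CCC(=O)O)cc3Cl)n2)c1`: 4580 nM
compound 2 `O=C(O)CCc1ccc(OCc2ncc(-c3cccc(Cl)c3)o2)cc1`: 47500 nM
compound 3 `O=C(O)CCc1ccc(OCc2coc(-c3cccc(F)c3)n2)cc1`: 560 nM

The three measured compounds share the same acid-bearing tail and differ in the five-membered ring and in the substituent on the pendant aromatic ring. In a functional assay on CHO cells for agonist activity at Free fatty acid receptor 1 (Homo sapiens), read by FLIPR and calcium flux, in the presence of a further agent that is not named here (a higher number here means that more compound is needed for the effect, a lower number that less compound is needed), compound 3 gives 560 nM. This is the lowest of the three numbers: compound 1 gives 4580 nM, and compound 2 gives 47500 nM, both lying beyond the scatter from compound 3. Each of the steps from compound 3 to the others is beyond the scatter. Compound 3 is thus the most potent of the measured set.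

Compound 4 `O=C(O)CCc1ccc(OCc2coc(-c3ccccc3)n2)cc1` has not yet been measured. It differs from compound 3 in one place: hydrogen in place of fluoro on an aromatic carbon, that is, 3-fluorophenyl becomes phenyl. Going by the values given here, no measured pair shows the effect of this change here, so no step can be drawn from the numbers. A single fluorine removed from an aromatic carbon is a small change, and for compound 4 in this assay a modest shift is expected, if any, most likely a slight rise, with the step of a 1.5-fold higher number from compound 3 to compound 4 (0.18 log units; within the scatter) expected to stay close to the scatter. The estimate for compound 4 is therefore 850 nM, within a range of 300 nM to 2500 nM.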

Compound 4, half-maximal effective concentration: 700 nM
Compound 4: the middle estimate sits 1.2-fold (0.08 log units) above what was measured, within the range that was stated.
By their numbers in this assay, from the lowest: compounds 3 and 4 (each within the scatter of the next); then compound 1; then compound 2.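

In this assay, going by these compounds alone, replacing fluoro with hydrogen gives the first step that can be read between compounds differing in one place, a 1.3-fold higher number from compound 3 to compound 4 (0.10 log units; within the scatter), and it stays within the scatter. On this aromatic carbon, meta to a large group, the fluorine therefore makes no measurable difference, and the change from 3-fluorophenyl to phenyl does not separate the two compounds. The low number of compound 3 does not require the fluorine, as compound 4, which carries an unsubstituted phenyl, gives 700 nM in this assay and stands with compound 3 at the low end of the set. Nothing measured here offers an explanation for this result.

The compounds shown leave open whether a methoxy, a trifluoromethyl, an amine or a chlorine at this place would also leave the number where it is, as only fluoro and hydrogen can be compared there. They also leave open whether the same exchange of fluoro for hydrogen would give so small a step on the cores of compound 1 and compound 2, which differ from compound 4 in more than one place.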